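Moving a hydroxyl group on a pyridine-based topoisomerase inhibitor

The compounds below may be only part of what the source reports. "The series", "measured", "known", "first", "only" and "open" are said of these compounds alone.

Measured compounds:
compound 1, `Oc1cccc(-c2cc(-c3ccoc3)cc(-c3cccc(O)c3)n2)c1`, 44.2%
compound 2, `Oc1cccc(-c2cc(-c3cccnc3)cc(-c3ccccc3O)n2)c1`, 1.9%

In an assay on isolated protein for inhibition of DNA topoisomerase 1 (Homo sapiens), with a stated time of 30 min, tested at 100 uM (on this read-out lower numbers stand for a weaker effect and higher numbers for a stronger effect at the one concentration tested), compound 2 gives 1.9%, the lowest of the two numbers; compound 1 stands a long way higher, beyond the usual scatter. Compound 3, `Oc1cccc(-c2cc(-c3cccnc3)cc(-c3cccc(O)c3)n2)c1`, differs from compound 2 in one place: 3-hydroxyphenyl in place of 2-hydroxyphenyl on an aromatic carbon. The resulting compound carries two 3-hydroxyphenyl groups like compound 1 does. For the measured compounds named here, no measured pair isolates this change, so the expectation rests on compound 1 alone. The step from compound 2 to compound 3 is expected to be an upward one of size a number 26.1 percentage points higher from compound 2 to compound 3 (beyond the scatter), beyond the scatter. Compound 3 is therefore estimated at 28%, within 4% to 55%.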

Compound 3, a percentage reported as inhibition, at one concentration (the size of the read-out at that concentration, not a potency): 2.1%
For compound 3 the middle estimate is 25.9 percentage points above the measured one; the measured number lies below the stated range.
By their numbers in this assay, from the lowest: compounds 2 and 3 (each within the scatter of the next); then compound 1.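

Swapping 2-hydroxyphenyl for 3-hydroxyphenyl gives a number 0.2 percentage points higher from compound 2 to compound 3 (within the scatter) and so, with pyridin-3-yl in the molecule, the two hydroxyl placements cannot be told apart. Sharing two 3-hydroxyphenyl groups with compound 1 is therefore not enough, since pyridin-3-yl in place of furan-3-yl gives a number 42.1 percentage points lower from compound 1 to compound 3 (beyond the scatter) as a large step. No supporting measurement accounts for either result. On these data alone, whether the hydroxyl placement matters alongside furan-3-yl remains open. So does how an aminomethyl or carboxylic acid group would fare at that aromatic carbon on the core.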